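The source may hold more compounds than are shown below. What is called first, only, known or untested is meant among the compounds shown, and "the series" means these compounds.

Measured compounds:
Compound 1 `COc1ccc(C2=NN(C3=NC(c4ccccc4)CS3)C(c3cccc4ccccc34)C2)cc1`, in a functional assay on BGC-823 cells (Homo sapiens) for inhibition, read by CCK-8 assay, with a stated time of 48 h (on this read-out lower numbers stand for stronger inhibition and higher numbers for weaker inhibition), gives 9510 nM.
Compound 2 `Cc1ccc(C2=NN(C3=NC(=O)CS3)C(c3ccc4ccccc4c3)C2)cc1` gives 7790 nM.
Compound 3 `COc1ccc(C2=NN(C3=NC(c4ccccc4)CS3)C(c3ccc4ccccc4c3)C2)cc1` gives 7250 nM.

Among these three, compound 1 carries the highest number, but its distance to compound 2 and to compound 3 lies within the scatter, so the three cannot be ranked. Within the data shown here, the one step that can be isolated, a 1.3-fold lower number from compound 1 to compound 3 (0.12 log units; within the scatter), changes nothing beyond the scatter. The step to compound 4 `Cc1ccc(C2=NN(C3=NC(c4ccccc4)CS3)C(c3cccc4ccccc34)C2)cc1` is of another kind: methyl in place of methoxy on an aromatic carbon. Among the measured compounds shown here, no measured pair isolates this exchange. Compound 2 also carries the methyl group on that ring, but it differs from compound 3 in a second place as well, so the values of compound 2 and compound 3 show only that both sit within the scatter of compound 1. With nothing in the data pointing to a shift, for compound 4 the expected step of a 1.1-fold lower number from compound 1 to compound 4 (0.02 log units; within the scatter) is none beyond the scatter. Compound 4 is therefore estimated at 9000 nM, within a range from 4000 nM to 20000 nM.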

Compound 4, half-maximal inhibitory concentration: 13300 nM
Compound 4: the middle estimate sits 1.5-fold (0.17 log units) below what was measured; low and high end bracket the measured number.
By their numbers in this assay, from the lowest: compounds 3, 2, 1 and 4 (each within the scatter of the next).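

Among these compounds, at this place, on an aromatic carbon para to a large group, this assay now gives a reading of the exchange of methoxy for methyl alone (a 1.4-fold higher number from compound 1 to compound 4 (0.15 log units; within the scatter)), which the earlier compounds could not isolate. On the core of compound 1, 4-methoxyphenyl can therefore give way to 4-methylphenyl, with the oxygen and its hydrogen-bond acceptor gone, without a shift beyond the scatter. Nothing available explains the small difference that the values show.

Going by these compounds, whether an amine, a carboxylic acid or a longer chain such as butoxy at this place would move the number beyond the scatter remains open. So does whether the same exchange reads alike when naphthalen-2-yl stands in place of naphthalen-1-yl.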